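The compounds below may be only part of what the source reports. "The series", "measured", "known", "first", "only" and "open" are said of these compounds alone.

In a functional assay (aorta) with Oryctolagus cuniculus as the target (on this read-out lower numbers stand for stronger inhibition and higher numbers for weaker inhibition), compound 1 `CC1=NC(C)=C(C(=O)OCCCN2C(=O)c3ccccc3S2(=O)=O)C(c2ccccc2C(F)(F)F)/C1=C(\O)OC(C)C` gives 2.7 nM and compound 2 `CC1=NC(C)=C(C(=O)OCCCN2C(=O)c3ccccc3S2(=O)=O)C(c2ccccc2C(F)(F)F)/C1=C(\O)OCC1CCCCO1` gives 1.4 nM so the two stand within the scatter of each other. Going by the values given here, the only measured step is a 1.9-fold lower number from compound 1 to compound 2 (0.29 log units; within the scatter) and it stays within the scatter, but it concerns the group on an oxygen on an unsaturated carbon. Compound 3 `CC1=NC(C)=C(C(=O)OCCCN2C(=O)c3ccccc3S2(=O)=O)C(c2ccccc2Cl)/C1=C(\O)OCC1CCCCO1` keeps that group of compound 2 and differs elsewhere: chloro in place of trifluoromethyl on an aromatic carbon with chloro in place of trifluoromethyl on an aromatic carbon, ortho to a large group. Among the compounds with values here, no measured pair varies this place, so no size or direction can be read from the data. The expectation therefore rests on compound 2 at 1.4 nM and no step beyond the scatter is expected. The estimated change is a 1.4-fold higher number from compound 2 to compound 3 (0.15 log units; within the scatter) and it remains only an expectation. For compound 3 the expected value is 2 nM with an estimated range from 0.6 nM to 7 nM until it is measured.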

Compound 3, half-maximal inhibitory concentration: 7 nM
Beside the measured number, compound 3's estimate is 3.5-fold (0.54 log units) below it; low and high end bracket the measured number.
By their numbers in this assay, from the lowest: compounds 2 and 1 (each within the scatter of the next); then compound 3.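

In this assay, the group on this aromatic carbon, ortho to a large group, makes a measurable difference: chloro in place of trifluoromethyl gives a 5.0-fold higher number from compound 2 to compound 3 (0.70 log units; beyond the scatter), with the rest of the molecule unchanged. Going by these compounds alone, this is the first step that lies beyond the scatter, whereas the change on the oxygen, a 1.9-fold lower number from compound 1 to compound 2 (0.29 log units; within the scatter), stayed within it. Nothing available here explains the size or direction of this step.

On these data alone, with only trifluoromethyl and chloro compared at this place, it remains open how other groups, such as methyl, bromo or methoxy, would fare there. As far as these compounds go, it is also open whether the swap from 2-(trifluoromethyl)phenyl to 2-chlorophenyl would give a similar step with isopropyl on the oxygen instead of (oxan-2-yl)methyl.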